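The compounds below may be only part of what the source reports. "The series", "measured", "known", "first", "only" and "open" are said of these compounds alone.

Compound 1 `O=C(/C=C/c1cccc(F)c1)c1ccccc1` — in a functional assay on RAW264.7 cells (Mus musculus) for inhibition, read by fluorescence, with stated times of 1 h, 24 h and 30 min (a higher number here means a weaker inhibitor, a lower number a stronger inhibitor), compound 1 gives > 10000 nM, a limit of the assay.
Compound 2 `O=C(/C=C/c1cccc(F)c1)c1ccccc1O` — in this assay compound 2 gives > 10000 nM, again a limit.

Compound 1 thus stands at the limit, the point at which every value shown sits (the limit of > 10000 nM in this assay, at which 2 of the 2 values shown sit). Among the compounds with values here, the only measured step, hydroxy in place of hydrogen on an aromatic carbon from compound 1 to compound 2, reads a step that the two limits leave unreadable from compound 1 to compound 2, so it offers no size. Compound 3 `O=C(/C=C/c1cccc(OC(F)(F)F)c1)c1ccccc1` differs from compound 1 by trifluoromethoxy in place of fluoro on an aromatic carbon. Within the data shown here, no measured step bears on this change, and the step in this assay is expected to be a step that the limit leaves unreadable from compound 1 to compound 3, most likely nothing readable. Compound 3 is therefore estimated at 15000 nM, in a range from 4000 nM to 60000 nM.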

Compound 3, half-maximal inhibitory concentration: > 10000 nM
Compound 3: only a limit was reported (the forecaster's own chance of this, stated with the estimate: 75%); the middle value is on the limit's open side.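

Compound 1 and compound 3 both stand at a limit in this assay, so no step between them can be read: the limit of > 10000 nM in this assay, at which 3 of the 3 values shown sit.

The compounds shown leave open how far each lies past that limit, and whether any change to the shared core gives a measurable value.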